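A few compounds are considered here, and "the series" means these few. Any claim that something is new, unique, unknown or untested is made for them only; others in the source may bear on it.

The series shares one core, shown in compound 1 `CCOC(=O)C1=Cc2ccccc2OC1(OCc1cn(CC(=O)Nc2ccccc2F)nn1)C(F)(F)F`, which in a functional assay on HeLa cells (Homo sapiens) for inhibition, read by MTT assay, with a stated time of 24 h (on this read-out lower numbers stand for stronger inhibition and higher numbers for weaker inhibition), gives 49900 nM. Compound 2 `CCOC(=O)C1=Cc2ccccc2OC1(OCc1cc(-c2ccc(Br)cc2)no1)C(F)(F)F` sits close to it, with 52300 nM in this assay, the two values lying within the usual scatter of each other, so no order between them can be read. Compound 3 `O=C(O)C1=Cc2ccccc2OC1(OCc1cc(-c2ccc(F)cc2F)no1)C(F)(F)F` returns only a limit of the assay in this assay, > 150000 nM, and not a number; (the limit of > 150000 nM in this assay, at which 1 of the 3 values shown sits). Compound 4 `CCOC(=O)C1=Cc2ccccc2OC1(OCc1cn(CC(=O)Nc2ccc(OC)cc2)nn1)C(F)(F)F` has not been measured. It differs from compound 1 by 4-methoxyphenyl in place of 2-fluorophenyl on an amide-type nitrogen. For the measured compounds named here, no measured step separates two compounds in one place here. The step expected from compound 1 to compound 4 is a 1.0-fold higher number from compound 1 to compound 4 (0.00 log units; within the scatter), judged to stay within the scatter. Compound 4 is therefore estimated at 50000 nM in this assay, between 20000 nM and 130000 nM.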

Compound 4, half-maximal inhibitory concentration: 31900 nM
Estimate against measurement, compound 4: 1.6-fold (0.20 log units) above; measured number inside the range.
By their numbers in this assay, from the lowest: compounds 4, 1 and 2 (each within the scatter of the next). At a limit, above all of these: compound 3.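

In this assay the first change read at this position, 4-methoxyphenyl in place of 2-fluorophenyl on the amide-type nitrogen, gives a 1.6-fold lower number from compound 1 to compound 4 (0.19 log units; within the scatter) and so sets no order between the two compounds. The position therefore accepts an added hydrogen-bond acceptor and the loss of fluorine without a step beyond the scatter. Nothing at hand bears on the reason for this step. Still open, going by these compounds, is whether an amine or a carboxylic acid in place of 4-methoxyphenyl on that nitrogen, or a longer chain ahead of the carbamoyl group, would give a step beyond the scatter.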